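Aryl variation on the triazole nitrogen: three limits

The source may report more compounds than this note shows. Statements on the series, on what has been measured and on what is new or still open speak of the compounds shown alone.

Compound 3 `N#CC1=C(N)Oc2c(N)cc3nc4ccccc4nc3c2C12C(=O)N(Cc1cnnn1-c1ccc(Cl)cc1Cl)c1ccccc12` belongs to a set of three analogues that differ only in the aryl group on an aromatic nitrogen of the five-membered aromatic ring with three nitrogens. In a functional assay on HCT-116 cells (Homo sapiens) for antiproliferative activity, read by MTT assay, with a stated time of 48 h (a higher number here means a weaker inhibitor, a lower number a stronger inhibitor), compound 3 gives > 50000 nM, which is a limit of the assay and not a number. Compound 1 `Cc1ccccc1-n1nncc1CN1C(=O)C2(C(C#N)=C(N)Oc3c(N)cc4nc5ccccc5nc4c32)c2ccccc21` in this assay gives > 50000 nM, again a limit. Compound 2 `COc1ccc(-n2nncc2CN2C(=O)C3(C(C#N)=C(N)Oc4c(N)cc5nc6ccccc6nc5c43)c3ccccc32)cc1` in this assay gives > 50000 nM, also a limit. Accordingly the steps a step that the two limits leave unreadable from compound 1 to compound 2, a step that the two limits leave unreadable from compound 1 to compound 3 and a step that the two limits leave unreadable from compound 2 to compound 3 cannot be sized; the whole set stands at the limit of > 50000 nM in this assay, at which 3 of the 3 values shown sit.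

Compound 4 `Cc1ccc(Cl)cc1-n1nncc1CN1C(=O)C2(C(C#N)=C(N)Oc3c(N)cc4nc5ccccc5nc4c32)c2ccccc21` carries the change (5-chloro-2-methylphenyl in place of 2,4-dichlorophenyl on an aromatic nitrogen). The three measured steps bear on it, since each exchanges the same aryl group, yet none is readable, so no direction can be drawn for this assay. The expected step that the limit leaves unreadable from compound 3 to compound 4 is therefore one that is expected to stay unreadable, with compound 4 most likely remaining at the limit. Compound 4 is estimated at 70000 nM, within 20000 nM to 250000 nM.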

Compound 4, half-maximal inhibitory concentration: 37200 nM
Compound 4: middle estimate off by 1.9-fold (0.27 log units), on the high side, and the stated range covers the measured number.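

Going by these compounds alone, compound 4 is the first member of this aryl set to give a number rather than a limit: in this assay compound 4 gives 37200 nM. The new steps are an at least 1.3-fold lower number from compound 3 to compound 4 (0.12 log units; that floor lies within the scatter), an at least 1.3-fold lower number from compound 2 to compound 4 (0.12 log units; that floor lies within the scatter) and an at least 1.3-fold lower number from compound 1 to compound 4 (0.12 log units; that floor lies within the scatter); the last of these is only chloro in place of hydrogen on an aromatic carbon, and each floor stays within the scatter, so none of the three establishes a real gain. The aryl position as a whole remains poorly responsive in what is shown: the limit of > 50000 nM in this assay, at which 3 of the 4 values shown sit.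

The steps among compound 1, compound 2 and compound 3 still cannot be read. Open, going by these compounds, is how this assay would respond to an aryl group carrying an amine or a carboxylic acid, or to a longer chain in place of the aryl group on the aromatic nitrogen.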